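This account rests on a few compounds, and the source may have more. Where it says the series, first, only, none or still open, it means among the compounds named here.

Compound 1 `O=C(O)/C(S)=C/c1c[nH]c2ccc(F)cc12` gives 930 nM in an assay on isolated protein for inhibition of Calpain-1 catalytic subunit (Sus scrofa); a lower number here means a stronger inhibitor, a higher number a weaker inhibitor.
Compound 2 `O=C(O)/C(S)=C/c1c[nH]c2ccc(I)cc12` gives 90 nM.
Compound 3 `O=C(O)/C(S)=C/c1ccccc1I` gives 42800 nM.

Compounds 1 and 2 share one core and compound 3 carries another; the difference between the two cores is not broken down here. Compound 3 stands highest of the three numbers, with compound 1 nearest and compound 2 furthest from it. Within the shared core of compounds 1 and 2, the change fluoro in place of iodo on an aromatic carbon produced a 10-fold higher number from compound 2 to compound 1 (1.01 log units; beyond the scatter).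

Compound 4 `O=C(O)/C(S)=C/c1ccccc1F` has not yet been measured and arises from compound 3 through (fluoro in place of iodo on an aromatic carbon). Among the compounds with values here, this is the same kind of change as the one from compound 2 to compound 1, but not the same change: in compound 1 the place is part of a fused or bridged system of two rings, meta to a fused ring and para to a fused ring, whereas in compound 4 the place is on a six-membered aromatic ring of carbon only, ortho to a group of 6 heavy atoms. Because a 10-fold higher number from compound 2 to compound 1 (1.01 log units; beyond the scatter) was beyond the scatter, the step from compound 3 to compound 4 is expected to run the same way, estimated as a 7.0-fold higher number from compound 3 to compound 4 (0.85 log units; beyond the scatter), with the differing surroundings of the place leaving its size less certain. Compound 4 is therefore expected to give about 300000 nM, with a likely range from 60000 nM to 1500000 nM.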

Compound 4, half-maximal inhibitory concentration: 23200 nM
Estimate against measurement, compound 4: 13-fold (1.11 log units) above; measured number outside the range, below it.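

In this assay, fluoro in place of iodo on an aromatic carbon of the core of compound 3 gives a 1.8-fold lower number from compound 3 to compound 4 (0.27 log units; within the scatter), so on this core the change does not separate the two compounds, whereas on the shared core of compounds 1 and 2 it gives a 10-fold higher number from compound 2 to compound 1 (1.01 log units; beyond the scatter), and the two steps differ: the same change on two cores in this assay, a 10-fold higher number (1.01 log units; beyond the scatter) from compound 2 to compound 1 and a 1.8-fold lower number (0.27 log units; within the scatter) from compound 3 to compound 4, 19-fold (1.28 log units) apart, beyond the scatter of two such steps This shows that, across these two pairs, the result of the change on one core did not carry over to the other, so the step seen on the core of compound 1 cannot simply be transferred to the core of compound 3. Within the data shown here, it does not show which difference between the two cores matters, and with only two pairs it sets no rule for any further core.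

The compounds shown leave open whether chloro or bromo at the same place would follow the steep course seen on the core of compound 1 or the flat one seen on the core of compound 3. They also leave open how a methyl or methoxy group at that place would behave on either core, and whether the two cores would again part ways.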